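Rearranging the trifluoro ether on a glycine transporter inhibitor

The source may report more compounds than this note shows. Statements on the series, on what has been measured and on what is new or still open speak of the compounds shown alone.

Three compounds share one core and were measured in an assay on CHO cells for inhibition of sodium- and chloride-dependent glycine transporter 1 (Homo sapiens), read by scintillation counting; on this read-out higher numbers stand for an effect only at larger amounts of compound and lower numbers for an effect already at smaller amounts. Compound 1 `C[C@H](Oc1ccc(S(C)(=O)=O)cc1C(=O)N1Cc2ccccc2C1)C(F)(F)F` gives 2540 nM in this assay. Compound 2 `C[C@H](Oc1ccc(S(C)(=O)=O)cc1C(=O)N1Cc2ccc(N3CCN(C)CC3)cc2C1)C(F)(F)F`, carrying 4-methylpiperazin-1-yl on an aromatic carbon, gives 2080 nM, and the step of a 1.2-fold lower number from compound 1 to compound 2 (0.09 log units; within the scatter) is within the scatter. Compound 3 `C[C@H](Oc1ccc(S(C)(=O)=O)cc1C(=O)N1Cc2ccc(C3CCOCC3)cc2C1)C(F)(F)F`, carrying oxan-4-yl on an aromatic carbon, gives 14 nM and stands lowest of the three; the steps of a 180-fold lower number from compound 1 to compound 3 (2.26 log units; beyond the scatter) and a 150-fold lower number from compound 2 to compound 3 (2.17 log units; beyond the scatter) are both large and beyond the scatter.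

Compound 4 `CS(=O)(=O)c1ccc(OCCC(F)(F)F)c(C(=O)N2Cc3ccc(C4CCOCC4)cc3C2)c1` keeps the oxan-4-yl group and differs from compound 3 only at the ether: 3,3,3-trifluoropropyl in place of 1-(trifluoromethyl)ethyl on an oxygen on an aromatic ring. Within the data shown here, none of the measured steps touches this position; all three measured compounds carry the same 1-(trifluoromethyl)ethyl group on that oxygen, and the only steps recorded concern the substituent on the aromatic carbon. There is therefore no measured basis for a change in either direction, and the expectation for this assay rests on compound 3 alone. The step of a 2.1-fold higher number from compound 3 to compound 4 (0.33 log units; beyond the scatter) is estimated to be small, with a wide range to allow for the untested change. Compound 4 is expected to give about 30 nM in this assay, between 7 nM and 150 nM.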

Compound 4, half-maximal effective concentration: 137 nM
Beside the measured number, compound 4's estimate is 4.6-fold (0.66 log units) below it, and the stated range covers the measured number.
By their numbers in this assay, from the lowest: compound 3; then compound 4; then compounds 2 and 1 (each within the scatter of the next).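

The ether oxygen on the aromatic ring, constant across compounds 1 to 3, turns out to matter for the read-out: with oxan-4-yl held fixed, this assay shows a 9.8-fold higher number from compound 3 to compound 4 (0.99 log units; beyond the scatter). Since 1-(trifluoromethyl)ethyl and 3,3,3-trifluoropropyl hold the same atoms joined differently, the step comes from the arrangement of that group and not from any change in its atom count or composition, and the change also removes the one defined stereocentre of the group. No measurement shown here offers an explanation for the size of this step.

Among these compounds, the single step cannot separate the loss of the stereocentre from the new place of the trifluoromethyl group, and it leaves open how the opposite configuration of 1-(trifluoromethyl)ethyl would read. Also open, from the compounds shown here alone, are how a longer chain such as 4,4,4-trifluorobutyl or a fluorine-free isopropyl group on that oxygen would compare, and whether the step would be of similar size with 4-methylpiperazin-1-yl or hydrogen in place of oxan-4-yl on the aromatic carbon.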